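Ether-to-Sulfoxide Swap and Cell Tolerance

This account rests on a few compounds, and the source may have more. Where it says the series, first, only, none or still open, it means among the compounds named here.

Measured so far:
Compound 1 `COc1ccc(-c2nc(COc3cccc(Cl)c3)nc3ccsc23)cn1` in an ADME assay on cells (Homo sapiens) for cytotoxicity, read by resazurin assay, with a stated time of 5 days (a higher number here means that more compound is tolerated, a lower number that less compound is tolerated), gives > 50000 nM.
Compound 2 `O=S(=O)(Cc1nc(-c2ccnc(Cl)c2)c2sccc2n1)c1cccc(Cl)c1` in this assay gives 63000 nM.

Compound 1 stands only at a limit, not at a number: its result in this assay is a limit of the measurement, as shown by the limit of > 50000 nM in this assay, at which 1 of the 2 values shown sits. Compound 2 reaches a number, and that number and the limit for compound 1 sit in the same high region, so both compounds are tolerated by the cells up to high concentrations.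

Compound 3 `COc1ccc(-c2nc(C[S+]([O-])c3cccc(Cl)c3)nc3ccsc23)cn1` is the unmeasured compound. It differs from compound 1 in one place: a group of 9 heavy atoms (6 carbon, 1 oxygen, 1 sulfur, 1 chlorine; one six-membered aromatic ring of carbon only) in place of a group of 8 heavy atoms (6 carbon, 1 oxygen, 1 chlorine; one six-membered aromatic ring of carbon only), on a saturated chain carbon bound to an aromatic carbon. Within the data shown here, no step between two measured compounds is available to gauge what such a change does here. The expected step that the limit leaves unreadable from compound 1 to compound 3 is therefore small, within the usual scatter, in no clear direction. On that basis compound 3 is estimated to give 55000 nM in this assay, with an expected range from 25000 nM to 120000 nM, and a fair chance that the measurement again returns only a limit.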

Compound 3, half-maximal cytotoxic concentration: > 50000 nM
Compound 3: no number, only a limit; the forecaster's own chance of this, stated with the estimate: 50%; the middle value is on the limit's open side.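

In this assay compound 1 and compound 3 both end at a limit rather than a number, so no step from one to the other can be read: the limit of > 50000 nM in this assay, at which 2 of the 3 values shown sit.

The compounds shown leave open whether replacing the 3-chlorophenoxy group with the sulfur-containing group changes cell tolerance at all, and at what concentration either compound would begin to harm the cells.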